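Swapping the amine on a dithiocarbamate chromone

The compounds below may be only part of what the source reports. "The series", "measured", "known", "first", "only" and "open" are said of these compounds alone.

Three compounds were tested in a functional assay on SW480 cells (Homo sapiens) for antiproliferative activity, read by MTT assay, with a stated time of 72 h; a higher number here means a weaker inhibitor, a lower number a stronger inhibitor. Compound 1 `O=c1c(SC(=S)N2CCCCC2)coc2ccccc12` gives 16300 nM. Compound 2 `CCOC(=O)c1cc(=O)c2cc(CSC(=S)N(C)c3ccccc3)ccc2o1` gives only > 25000 nM, which is a limit of the assay and not a number. Compound 3 `O=c1cc(CSC(=S)N2CCCC2)oc2cc(Cl)ccc12` likewise gives only > 25000 nM, again a limit rather than a number. Compound 2 therefore stands at the weak end of what has been seen: its result is the limit of > 25000 nM in this assay, at which 2 of the 3 values shown sit, so it is among the compounds for which no measurable inhibition was found. No two of the three measured compounds differ in a single place, so no measured step can be read off from them directly.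

Compound 4 `CCOC(=O)c1cc(=O)c2cc(CSC(=S)N3CCCC3)ccc2o1` is the untested member. It differs from compound 2 in one place: pyrrolidin-1-yl in place of methyl(phenyl)amino on a thiocarbonyl carbon. Compound 3, which also carries pyrrolidin-1-yl on its thiocarbonyl carbon, sits at the same limit as compound 2, so the change is expected to move the value from compound 2 to compound 4 by a number no higher from compound 2 to compound 4 (the limit leaves the size open), that is, not beyond the usual scatter. Compound 4 is expected to come out near 25000 nM, within a range from 8000 nM to 60000 nM, with a real chance that the assay again reports only a limit.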

Compound 4, half-maximal inhibitory concentration: > 25000 nM
Compound 4 ended at the assay's limit (the forecaster's own chance of this, stated with the estimate: 55%); the middle value sits exactly at the limit.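

Compound 2 and compound 4 each end at a limit of the assay, not at a number, so no step between them can be read: the limit of > 25000 nM in this assay, at which 3 of the 4 values shown sit.

The compounds shown leave open whether pyrrolidin-1-yl in place of methyl(phenyl)amino on a thiocarbonyl carbon changes the activity at all, and how far past the limit either compound lies.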